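A few compounds are considered here, and "the series" means these few. Any claim that something is new, unique, unknown or untested is made for them only; others in the source may bear on it.

Two compounds share a urea-linked pyrazole core and differ only in the substitution of the aryl ring attached to the pyrazole nitrogen. In an assay on CHO-K1 cells for antagonist activity at transient receptor potential cation channel subfamily V member 1 (Homo sapiens), read by FLIPR and calcium flux, with a stated time of 6 min (a higher number here means a weaker inhibitor, a lower number a stronger inhibitor), compound 1 `CC(C)(C)c1cc(CNC(=O)Nc2cccc3[nH]ncc23)n(-c2ccc(F)cc2)n1` gives 2.2 nM. Compound 2 `CC(C)(C)c1cc(CNC(=O)Nc2cccc3[nH]ncc23)n(-c2ccc(F)c(F)c2)n1` carries an extra fluoro and in this assay compound 2 gives 0.5 nM. Among the compounds with values here, that single measured step, a 4.4-fold lower number from compound 1 to compound 2 (0.64 log units; beyond the scatter), is the only comparison available, and it places compound 2 at the lowest of the two numbers, with compound 1 as its nearest neighbour.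

Compound 3 `CC(C)(C)c1cc(CNC(=O)Nc2cccc3[nH]ncc23)n(-c2ccc(F)c(Cl)c2)n1` is the next variation on this theme. Relative to compound 2 the change is chloro in place of fluoro on an aromatic carbon. Within the data shown here, no measured step shows what a chloro does at this site; the one step that bears on the position, a 4.4-fold lower number from compound 1 to compound 2 (0.64 log units; beyond the scatter), only shows that a halogen there is tolerated and favourable. Among the measured compounds shown here, with a single halogen-for-halogen swap and no precedent, the expectation is a step of roughly a 1.2-fold higher number from compound 2 to compound 3 (0.08 log units; within the scatter) in this assay, not beyond the scatter in either direction. Compound 3 is therefore estimated at 0.6 nM, with a range from 0.15 nM to 2.5 nM.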

Compound 3, inhibition constant: 0.5 nM
Estimate against measurement, compound 3: 1.2-fold (0.08 log units) above; the measured number falls inside the stated range.
By their numbers in this assay, from the lowest: compounds 2 and 3 (each within the scatter of the next); then compound 1.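

In this assay, the change from 3,4-difluorophenyl to 3-chloro-4-fluorophenyl gives no change at the digits printed from compound 2 to compound 3 (within the scatter), so on this aromatic carbon, ortho to a fluoro group and meta to a large group, the assay does not separate chloro from fluoro. Measured against hydrogen on the same carbon, chloro gives a 4.4-fold lower number from compound 1 to compound 3 (0.64 log units; beyond the scatter), a step of the same size as the one for fluoro, a 4.4-fold lower number from compound 1 to compound 2 (0.64 log units; beyond the scatter), so the earlier gain is not confined to fluoro but is shared by the two halogens shown here. Nothing measured here accounts for the match between the two halogens.

As far as these compounds go, it remains open whether this carbon keeps such low numbers with bromo, or with a group that is not a halogen, such as methyl, methoxy, trifluoromethyl or an amine. From the compounds shown here alone, it is also open how much the fluoro group common to compound 1, compound 2 and compound 3 contributes, since all three carry it and none shows hydrogen or chloro in its place.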